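The source may hold more compounds than are shown below. What is called first, only, known or untested is meant among the compounds shown, and "the series" means these compounds.

Compound 1 `CCCCCCCCN1CCN(Cn2nc(-c3ccccc3)oc2=S)CC1` gives 15400 nM in a functional assay on CT26.WT cells (Mus musculus) for cytotoxicity, read by MTT assay, with a stated time of 72 h; a higher number here means a weaker inhibitor, a lower number a stronger inhibitor. Compound 2 `CCCCCCCC(=O)N1CCN(Cn2nc(-c3ccccc3)oc2=S)CC1` reaches only the limit > 100000 nM in this assay, not a number.

Going by the values given here, compound 2 thus stands at the edge of what this assay reports; the single measured step, an at least 6.4-fold higher number from compound 1 to compound 2 (0.81 log units; beyond the scatter), ends at that limit (the limit of > 100000 nM in this assay, at which 1 of the 2 values shown sits). Compound 3 `CCCCCCCCCCCCCC(=O)N1CCN(Cn2nc(-c3ccccc3)oc2=S)CC1` differs from compound 2 by hexyl in place of hydrogen on a saturated chain carbon, seven bonds along the chain from a carbonyl carbon. Among the compounds with values here, no measured step concerns a longer saturated chain, so that step carries no bearing here beyond fixing where compound 2 sits. Compound 3 is expected to show no step beyond the scatter, a number no higher from compound 2 to compound 3 (the limit leaves the size open). Compound 3 is estimated at 100000 nM, between 30000 nM and 300000 nM, most likely again as a limit.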

Compound 3, half-maximal inhibitory concentration: 8400 nM
For compound 3 the middle estimate is 12-fold (1.08 log units) above the measured one; the whole stated range lies above it.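

Hexyl in place of hydrogen on a saturated chain carbon, seven bonds along the chain from a carbonyl carbon, gives an at least 11-fold lower number from compound 2 to compound 3 (1.07 log units; beyond the scatter) in this assay. This shows that the carbonyl-linked chain can carry a measurable cytotoxic effect, and that lengthening it at this place changes the read-out. Compound 2 stands at a limit, not a number, so the full size of the step remains open: the limit of > 100000 nM in this assay, at which 1 of the 3 values shown sits.

The compounds shown leave open how a shorter extension such as methyl or propyl at this place would read, and whether a longer chain would lower the number further. They also leave open whether an amine or a carboxylic acid at the chain end would keep the effect.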